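Compound 3: replacing the indole group with 4-(tert-butyl)phenyl

A few compounds are considered here, and "the series" means these few. Any claim that something is new, unique, unknown or untested is made for them only; others in the source may bear on it.

- Compound 1 `COc1cc(-c2ccnc3cc(-c4c[nH]c5ccccc45)nn23)cc(OC)c1OC` gives 195 nM in a functional assay on HeLa cells (Homo sapiens) for inhibition, read by CCK-8 assay, with a stated time of 48 h; on this read-out lower numbers stand for stronger inhibition and higher numbers for weaker inhibition
- Compound 2 `COc1cc(-c2ccnc3cc(-c4ccc5ccn(C)c5c4)nn23)cc(OC)c1OC` gives 187 nM in this assay

Compound 2 stands level with compound 1 on these numbers, so neither can be ranked above the other. The next compound is compound 3 `COc1cc(-c2ccnc3cc(-c4ccc(C(C)(C)C)cc4)nn23)cc(OC)c1OC`, which carries 4-(tert-butyl)phenyl in place of 1-methyl-1H-indol-6-yl on an aromatic carbon of the five-membered aromatic ring with 2 nitrogen. The counted difference is 4-(tert-butyl)phenyl in place of 1-methyl-1H-indol-6-yl on an aromatic carbon and the rest of the structure stays the same.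

Among the compounds with values here, only one measured step bears on this change. It is a 1.0-fold lower number from compound 1 to compound 2 (0.02 log units; within the scatter) and it exchanged 1H-indol-3-yl for 1-methyl-1H-indol-6-yl at the same place. Neither compound 1 nor compound 2 carries 4-(tert-butyl)phenyl, so the data do not test a group of this kind and offer only a weak guide. A modest move toward weaker inhibition is expected, held with little confidence. The expected size of this move is a 1.9-fold higher number from compound 2 to compound 3 (0.27 log units; within the scatter) in this assay for now. For compound 3 the estimated value is 350 nM, with an expected range from 100 nM to 1500 nM in this assay when it is measured.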

Compound 3, half-maximal inhibitory concentration: > 10000 nM
Compound 3 ended at the assay's limit; the forecaster's own chance of this, stated with the estimate: 5%; middle value at least 28-fold (1.45 log units) from the limit.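

Compound 3 ended at a limit of this assay, which is not a number: the limit of > 10000 nM in this assay, at which 1 of the 3 values shown sits.

The two indole compounds had shown no readable difference between them, so they gave no sign of how much the group at this place matters. The exchange for 4-(tert-butyl)phenyl now shows that it matters a great deal, with an at least 53-fold higher number from compound 2 to compound 3 (1.72 log units; beyond the scatter) and an at least 51-fold higher number from compound 1 to compound 3 (1.70 log units; beyond the scatter). The entering group has the same count of 10 heavy atoms as 1-methyl-1H-indol-6-yl, so an equal heavy-atom count at this place, on the five-membered aromatic ring with 2 nitrogen, does not by itself preserve inhibition.

This single change removes the second ring and the ring nitrogen and adds the tert-butyl group all at once, so the compounds shown cannot say which of these differences accounts for the large step. As far as these compounds go, an unsubstituted phenyl, a phenyl carrying an amine, or a pyridine ring at this place would be needed to tell these differences apart, and whether any group other than an indole keeps inhibition here remains open.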